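This account rests on a few compounds, and the source may have more. Where it says the series, first, only, none or still open, it means among the compounds named here.

Three measured compounds:
Compound 1 `COc1cc(O)cc(O)c1C(=O)/C=C/c1ccc(O)cc1`; in a functional assay on A549 cells (Homo sapiens) for inhibition, read by MTT assay, with a stated time of 72 h (a lower number here means a stronger inhibitor, a higher number a weaker inhibitor), compound 1 gives > 50000 nM, a limit of the assay.
Compound 2 `COc1cc(/C=C/C(=O)c2c(O)cc(O)cc2OC)ccc1O`; compound 2 gives > 50000 nM, also a limit.
Compound 3 `COc1ccc(/C=C/C(=O)c2c(O)cc(O)cc2OC)cc1OC`; compound 3 gives > 50000 nM, again a limit.

All three sit at the limit of > 50000 nM in this assay, at which 3 of the 3 values shown sit. The change methoxy in place of hydrogen on an aromatic carbon gave a step that the two limits leave unreadable from compound 1 to compound 2, and the next change gave a step that the two limits leave unreadable from compound 2 to compound 3. Compound 4 `COc1cc(OC)c(OC)cc1/C=C/C(=O)c1c(O)cc(O)cc1OC` carries the same kind of change, (methoxy in place of hydrogen on an aromatic carbon), though its surroundings differ: ortho to a large group, meta to a methoxy group and para to a methoxy group, rather than ortho to a hydroxy group and meta to a large group. The difference between the two cores is not broken down here. Since compound 3 gives > 50000 nM, compound 4 is expected to remain near that limit, with an estimated step that the limit leaves unreadable from compound 3 to compound 4. Compound 4 is therefore estimated at 60000 nM, between 20000 nM and 200000 nM.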

Compound 4, half-maximal inhibitory concentration: 34200 nM
Compound 4: middle estimate off by 1.8-fold (0.24 log units), on the high side, and the stated range covers the measured number.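

In this assay, methoxy in place of hydrogen on an aromatic carbon, here ortho to a large group, gave an at least 1.4-fold lower number from compound 3 to compound 4 (0.16 log units; that floor lies within the scatter). The two earlier steps cannot be read, as both ends of each are limits of the assay: the limit of > 50000 nM in this assay, at which 3 of the 4 values shown sit. Going by these compounds alone, the series therefore shows one readable floor for this change on one core, and it does not show that the change carries from one core to another, since no two readable steps can be set side by side.

The compounds shown leave open what an amine, a carboxylic acid or a longer chain such as ethoxy would give at this place. They also leave open whether any such group would give a step beyond the scatter.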